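A few compounds are considered here, and "the series" means these few. Any claim that something is new, unique, unknown or untested is made for them only; others in the source may bear on it.

Compound 2 `NS(=O)(=O)c1ccc(NC(=S)Nc2ccc3ncnc(Nc4cccc(C(F)(F)F)c4)c3c2)cc1` and compound 1 `COc1cc2ncnc(Nc3ccc(C(F)(F)F)cc3)c2cc1OCCCCC(=O)Nc1ccc(S(N)(=O)=O)cc1` were both tested in a functional assay on NCI-H1975 cells (Homo sapiens) for antiproliferative activity, read by MTT assay, with a stated time of 72 h; on this read-out lower numbers stand for stronger inhibition and higher numbers for weaker inhibition. Compound 2 gives 7590 nM, and compound 1 gives 12000 nM; the two numbers lie within the scatter of each other, so neither can be set apart. Compound 3 `NS(=O)(=O)c1ccc(NC(=S)Nc2ccc3ncnc(Nc4cccc(F)c4)c3c2)cc1` is the untested partner of compound 2, differing by fluoro in place of trifluoromethyl on an aromatic carbon. Among the measured compounds shown here, no measured pair covers this change, so the expectation for compound 3 is a small rise in this assay value, a step of a 1.8-fold higher number from compound 2 to compound 3 (0.27 log units; within the scatter) from compound 2, barely beyond the scatter. Compound 3 is therefore expected at 14000 nM, between 5000 nM and 40000 nM.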

Compound 3, half-maximal inhibitory concentration: 9660 nM
For compound 3 the middle estimate is 1.4-fold (0.16 log units) above the measured one; the range from low to high includes it.
By their numbers in this assay, from the lowest: compounds 2, 3 and 1 (each within the scatter of the next).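

Setting fluoro in place of trifluoromethyl on this aromatic carbon gives a 1.3-fold higher number from compound 2 to compound 3 (0.10 log units; within the scatter) in this assay. The change from 3-(trifluoromethyl)phenyl to 3-fluorophenyl therefore leaves the read-out unresolved, and on this thiourea-linked series the two groups cannot be told apart at this place. No measurement at hand bears on this result. Still open, on these data alone, is whether an amine, a carboxylic acid or a methoxy group on the same aromatic carbon would move the number beyond the scatter. Also open, as far as these compounds go, is whether fluoro and trifluoromethyl would stay indistinguishable on the core of compound 1.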